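A Chlorophenyl Amide Awaiting Its Cell Assay Number

The compounds below may be only part of what the source reports. "The series", "measured", "known", "first", "only" and "open" are said of these compounds alone.

Three amides sharing one core have been tested in a functional assay on L02 cells (Homo sapiens) for inhibition, read by MTT assay, with a stated time of 48 h; on this read-out lower numbers stand for stronger inhibition and higher numbers for weaker inhibition. Compound 1 `COc1ccc(CNC(=O)/C=C/c2coc3cc(O)ccc3c2=O)cc1` gives > 200000 nM in this assay, which is a limit of the assay rather than a number. Compound 3 `Cc1ccccc1NC(=O)/C=C/c1coc2cc(O)ccc2c1=O` gives > 200000 nM in this assay, again a limit. Compound 2 `COc1cccc(NC(=O)/C=C/c2coc3cc(OC)ccc3c2=O)c1` gives > 200000 nM in this assay, also a limit. Compound 2 thus stands exactly where the other two stand, at the limit of > 200000 nM in this assay, at which 3 of the 3 values shown sit, and no measured value tells any of the three apart.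

Compound 4 `COc1ccc2c(=O)c(/C=C/C(=O)Nc3ccc(Cl)cc3)coc2c1` differs from compound 2 in one place: 4-chlorophenyl in place of 3-methoxyphenyl on an amide-type nitrogen. Going by the values given here, every measured compound rests at the same limit; no measured step exists to guide what this change might do. The expected step is therefore a number no higher from compound 2 to compound 4 (the limit leaves the size open), meaning no change beyond the scatter is expected. Compound 4 is expected to give near 200000 nM in this assay, estimated between 80000 nM and 500000 nM, and most likely to be reported once more only as a limit.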

Compound 4, half-maximal inhibitory concentration: > 200000 nM
Compound 4 ended at the assay's limit (the forecaster's own chance of this, stated with the estimate: 80%); the middle value lies on the limit itself.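

Compound 2 and compound 4 both rest at a limit rather than a number, so no step between them can be read: the limit of > 200000 nM in this assay, at which 4 of the 4 values shown sit.

The compounds shown leave open whether 4-chlorophenyl and 3-methoxyphenyl on the amide-type nitrogen differ at all, and whether any compound sharing this core would give a true number.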